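The source may hold more compounds than are shown below. What is called first, only, known or untested is meant among the compounds shown, and "the series" means these compounds.

Compound 1 `Nc1cc(N)c2nc(-c3ccccc3)c(NCc3ccc(Cl)c(Cl)c3)nc2c1`: 17400 nM
Compound 2 `COc1cc(CNc2nc3cc(N)cc(N)c3nc2-c2ccccc2)cc(OC)c1OC`: 6310 nM

The study measured growth inhibition in a functional assay on A498 cells (Homo sapiens) for inhibition, read by sulforhodamine B assay, with a stated time of 48 h; on this read-out lower numbers stand for stronger inhibition of growth and higher numbers for weaker inhibition of growth. Going by the values given here, of the two compounds measured so far, compound 1 carries the highest number, with 17400 nM; compound 2 gives 6310 nM, a lower number, and the gap between the two lies beyond the usual scatter. Both share the same core and differ only in the group on the chain carbon bound to the ring nitrogen.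

Compound 3 `COc1ccc(CNc2nc3cc(N)cc(N)c3nc2-c2ccccc2)cc1` has not yet been measured. It differs from compound 1 by 4-methoxyphenyl in place of 3,4-dichlorophenyl on a saturated chain carbon bound to a nitrogen on an aromatic ring. Among the compounds with values here, with no measured pair that isolates this exact change, the expectation rests on compound 1 and compound 2 alone. The step from compound 1 to compound 3 is expected to be a 1.7-fold lower number from compound 1 to compound 3 (0.24 log units; within the scatter), a modest movement toward a lower number that may not clear the scatter. Compound 3 is therefore estimated to give 10000 nM in this assay, with a range from 3500 nM to 30000 nM.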

Compound 3, concentration for 50% growth inhibition: < 100000 nM
Compound 3 gave a limit, no number; the forecaster's own chance of this, stated with the estimate: 5%; the middle value is on the limit's open side.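

Compound 3 gave < 100000 nM, which is a limit and not a number. The step between compound 1 and compound 3 cannot be read from it. The compounds shown leave open whether, and how far, 4-methoxyphenyl in place of 3,4-dichlorophenyl shifts growth inhibition.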